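A Methyl Branch on the Amide Side Chain

The source may hold more compounds than are shown below. What is called first, only, known or untested is meant among the compounds shown, and "the series" means these compounds.

Compound 1 `CCN(Cc1ccccc1)C(=O)C1CCN(S(=O)(=O)c2ccc(C(F)(F)F)nc2)CC1` has in a functional assay on CHO cells for positive allosteric modulation of muscarinic acetylcholine receptor M5 (Homo sapiens), read by calcium flux (on this read-out higher numbers stand for larger maximal responses and lower numbers for smaller maximal responses), only the entry "not determined" (no result reported) and therefore gives no footing here. Within the data shown here, compound 2 `CCCN(Cc1ccccc1C(F)(F)F)C(=O)C1CCN(S(=O)(=O)c2ccc3[nH]ncc3c2)CC1` is the only compound with a number: in this assay compound 2 reaches 94%, the sole value shown, the one further entry carrying no single number. Compound 3 `CCC(C)N(Cc1ccccc1C(F)(F)F)C(=O)C1CCN(S(=O)(=O)c2ccc3[nH]ncc3c2)CC1` differs from compound 2 by methyl in place of hydrogen on a saturated chain carbon bound to an amide-type nitrogen and a saturated chain carbon. Among the measured compounds shown here, no step between two measured compounds is recorded, so the size of this change has no measured precedent. One carbon entering a saturated chain at the position described is a small change, and no move beyond the usual scatter is expected in this assay. Relative to compound 2, compound 3 is expected to reach about 90%, with a range from 70% to 108%. The expected step of a number 4 percentage points lower from compound 2 to compound 3 (within the scatter) is estimated to lie within the usual scatter of this read-out.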

Compound 3, largest response reached (reported as percent of maximum), in percent of the reference or control that the assay uses: 100%
Estimate against measurement, compound 3: 10 percentage points below; the measured number falls inside the stated range.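

In this assay, among these compounds, the exchange of propyl for sec-butyl gives a number 6 percentage points higher from compound 2 to compound 3 (within the scatter) and thereby supplies the first measured step at this position. It shows that a methyl in place of hydrogen on a saturated chain carbon bound to an amide-type nitrogen and a saturated chain carbon does not move the maximal response beyond the usual scatter, so this branch is tolerated on this read-out. No measurement shown here bears on the reason for this.

This single step leaves open how far the position tolerates larger changes, such as a tert-butyl group, a longer chain or a chain carrying an amine. The maximal response also leaves open how the methyl affects the concentration needed to reach that response.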